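The source may report more compounds than this note shows. Statements on the series, on what has been measured and on what is new or still open speak of the compounds shown alone.

Measured in a functional assay on T-24 cells (Homo sapiens) for antiproliferative activity, read by MTT assay, with a stated time of 48 h; on this read-out lower numbers stand for stronger inhibition and higher numbers for weaker inhibition:
compound 1 `Cc1ccc(NC(=O)Nc2cccc(CNc3nccnc3Cl)c2)cc1C` gives 8930 nM;
compound 2 `O=C(Nc1ccccc1)Nc1cccc(CNc2nccnc2Cl)c1` gives 19800 nM;
compound 3 `CC(C)(C)c1ccc(NC(=O)Nc2cccc(CNc3nccnc3Cl)c2)cc1` gives 6010 nM.

Compound 3 has the lowest of the three numbers, though compound 1 lies within the scatter of it; only compound 2 stands beyond it. Compound 4 `CS(=O)(=O)c1ccc(NC(=O)Nc2cccc(CNc3nccnc3Cl)c2)cc1` differs from compound 3 by methylsulfonyl in place of tert-butyl on an aromatic carbon. Among the measured compounds shown here, no measured step swaps one group for another at this place. For the measured compounds named here, the closest precedent is a 3.3-fold lower number from compound 2 to compound 3 (0.52 log units; beyond the scatter), where tert-butyl entered in place of hydrogen; a 2.2-fold higher number from compound 1 to compound 2 (0.35 log units; beyond the scatter) points the same way when substituents are removed. Methylsulfonyl itself has no precedent here, so losing the tert-butyl is the main consideration. Compound 4 is therefore expected to give a higher number, estimated at 15000 nM with a range of 6000 nM to 40000 nM. That estimate means a 2.5-fold higher number from compound 3 to compound 4 (0.40 log units; beyond the scatter).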

Compound 4, half-maximal inhibitory concentration: 29300 nM
Estimate against measurement, compound 4: 2.0-fold (0.29 log units) below, and the stated range covers the measured number.
By their numbers in this assay, from the lowest: compounds 3 and 1 (each within the scatter of the next); then compounds 2 and 4 (each within the scatter of the next).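

Measured in this assay the exchange of tert-butyl for methylsulfonyl gives a 4.9-fold higher number from compound 3 to compound 4 (0.69 log units; beyond the scatter) and shows that the outcome at this place, para to a large group, depends strongly on which group stands there. Set against hydrogen, methylsulfonyl gives a 1.5-fold higher number from compound 2 to compound 4 (0.17 log units; within the scatter) and so brings no change that can be told from the scatter: a substituent here does not lower the number as such, since tert-butyl in compound 3 does and methylsulfonyl in compound 4 does not. Nothing available explains this difference between the two groups. On these data alone, whether an amine, a methoxy group or a carboxylic acid at this place would follow tert-butyl or methylsulfonyl stays open.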